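The source may hold more compounds than are shown below. What is called first, only, known or untested is meant among the compounds shown, and "the series" means these compounds.

In a functional assay on cells (Homo sapiens) for antiproliferative activity, read by sulforhodamine B assay, with a stated time of 48 h (a higher number here means a weaker inhibitor, a lower number a stronger inhibitor), compound 1 (`CCCCCCCCNC(=O)[C@@H]1CSC(c2cc(OC)c(OC)c(OC)c2)N1`) gives 17100 nM, compound 2 (`CCCCCCCCCCNC(=O)[C@@H]1CSC(c2cc(OC)c(OC)c(OC)c2)N1`) gives 14500 nM and compound 3 (`CCCCCCCCCCNC(=O)[C@@H]1CSC(c2ccc(OC)c(OC)c2)N1`) gives 11900 nM. Compound 3 therefore lies within the scatter of both other compounds, and the three cannot be ranked. Compound 4 (`CCCCCCCCCCCCCCCCNC(=O)[C@@H]1CSC(c2ccc(OC)c(OC)c2)N1`) differs from compound 3 by hexyl in place of hydrogen on a saturated chain carbon, ten or more bonds along the chain from an amide-type nitrogen.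

For the measured compounds named here, the closest precedent is a 1.2-fold lower number from compound 1 to compound 2 (0.07 log units; within the scatter), which also extends the chain, though only with ethyl in place of hydrogen, and stays within the scatter. The other measured step, a 1.2-fold lower number from compound 2 to compound 3 (0.09 log units; within the scatter), is also within the scatter, but it concerns an aromatic carbon and says little about the chain. Going by the values given here, no measured compound carries a chain as long as that of compound 4, so any extrapolation is uncertain. Hexyl is a larger addition than ethyl, so a modest move towards a lower number in this assay is expected, which may just clear the scatter. The expected change is a 2.4-fold lower number from compound 3 to compound 4 (0.38 log units; beyond the scatter). For compound 4 the estimate is 5000 nM, with an expected range of 1500 nM to 14000 nM.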

Compound 4, half-maximal inhibitory concentration: 1500 nM
Compound 4: middle estimate off by 3.3-fold (0.52 log units), on the high side, within the range that was stated.
By their numbers in this assay, from the lowest: compound 4; then compounds 3, 2 and 1 (each within the scatter of the next).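

In this assay, for the compounds shown here, hexyl in place of hydrogen on a saturated chain carbon gives a 7.9-fold lower number from compound 3 to compound 4 (0.90 log units; beyond the scatter) and is the first chain change here to clear the scatter, whereas the smaller ethyl addition gave only a 1.2-fold lower number from compound 1 to compound 2 (0.07 log units; within the scatter) and stayed within it. The number in this assay therefore does respond to what is added at the far end of the chain, which the earlier pair could not show, although this rests on a single step on one aryl pattern. Nothing available explains the drop.

From the compounds shown here alone, it remains open whether the same hexyl addition would give a comparable step on compound 2, which keeps the third methoxy group. Going by these compounds, it is also open whether a still longer chain, or a chain ending in an amine or a carboxylic acid, would extend this trend or reverse it.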